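From Methoxy to Chloro: What to Expect for Compound 4

This account rests on a few compounds, and the source may have more. Where it says the series, first, only, none or still open, it means among the compounds named here.

Three measured compounds share one core and differ only at a single aromatic position or in configuration. Compound 1 `C=C1C(=O)OC[C@H]1CCOC(=O)Nc1ccc(I)cc1` carries an iodo group, and in an ADME assay on RAW264.7 cells (Mus musculus) for cytotoxicity, read by MTT assay, with a stated time of 18 h (a higher number here means that more compound is tolerated, a lower number that less compound is tolerated), compound 1 gives 12800 nM. Compound 2 `C=C1C(=O)OC[C@H]1CCOC(=O)Nc1ccc(OC)cc1` carries a methoxy group instead; in this assay compound 2 gives 12400 nM. Compound 3 `C=C1C(=O)OC[C@@H]1CCOC(=O)Nc1ccc(OC)cc1` has the same atoms and bonds as compound 2 and differs only in configuration; in this assay compound 3 gives 11900 nM. Compound 2 stands second highest of the three numbers, yet both neighbours sit within the scatter of it: a 1.0-fold lower number from compound 1 to compound 2 (0.01 log units; within the scatter) and a 1.0-fold lower number from compound 2 to compound 3 (0.02 log units; within the scatter), the latter resting on (the fact that compounds 2 and 3 differ only in the configuration as drawn).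

Among the compounds with values here, compound 4 `C=C1C(=O)OC[C@H]1CCOC(=O)Nc1ccc(Cl)cc1` has not yet been measured. chloro in place of methoxy on an aromatic carbon The one measured step at the same position, a 1.0-fold lower number from compound 1 to compound 2 (0.01 log units; within the scatter), exchanged a halogen for methoxy and left the number essentially where it was. A step of that size, none beyond the scatter, is therefore expected for the reverse kind of exchange here. In this assay compound 4 is estimated at 12500 nM, with a range from 7000 nM to 22000 nM. That estimate means an expected 1.0-fold higher number from compound 2 to compound 4 (0.00 log units; within the scatter), a change not beyond the scatter.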

Compound 4, half-maximal cytotoxic concentration: 9140 nM
Compound 4: the middle estimate sits 1.4-fold (0.14 log units) above what was measured, and the stated range covers the measured number.
By their numbers in this assay, from the lowest: compounds 4, 3, 2 and 1 (each within the scatter of the next).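

In this assay, chloro in place of methoxy gives a 1.4-fold lower number from compound 2 to compound 4 (0.13 log units; within the scatter) and chloro in place of iodo gives a 1.4-fold lower number from compound 1 to compound 4 (0.15 log units; within the scatter) and so neither step leaves the scatter. The earlier compounds shown here showed only iodo and methoxy on this aromatic carbon, para to a large group, and with chloro added, compounds 1, 2 and 4 show three different groups there whose numbers cannot be told apart, a pattern that no compound with a group at this place goes against but that reaches no further than these compounds. Nothing available here bears on why the exchange of these groups leaves the number within the scatter.

Still open, as far as these compounds go, is whether a group of another kind at this place, such as an amine, a carboxylic acid or a longer chain, would give a step beyond the scatter. From the compounds shown here alone, only the methoxy compounds appear in both configurations, so it also remains open whether the configuration as drawn would stay without a visible effect with chloro or iodo on the aromatic ring.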